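Difluorophenyl Analogue Joins a Series Without Measurable Activity

This account rests on a few compounds, and the source may have more. Where it says the series, first, only, none or still open, it means among the compounds named here.

Of the compounds shown here, three built on one shared core have been tested in a functional assay on PANC-1 cells (Homo sapiens) for inhibition, read by MTT assay, with a stated time of 48 h; on this read-out higher numbers stand for weaker inhibition and lower numbers for stronger inhibition. Compound 1 `Cc1nnsc1CO/N=C/c1c(C)nn(C)c1Oc1ccccc1Cl` gives > 50000 nM, which is a limit of the assay rather than a number. Compound 2 `Cc1nnsc1CO/N=C/c1c(C)nn(C)c1Oc1ccc(I)cc1` likewise reaches only the limit > 50000 nM in this assay. Compound 3 `Cc1ccc(Oc2c(/C=N/OCc3snnc3C)c(C)nn2C)cc1` also stops at the limit, > 50000 nM in this assay. The steps a step that the two limits leave unreadable from compound 1 to compound 2, a step that the two limits leave unreadable from compound 1 to compound 3 and a step that the two limits leave unreadable from compound 2 to compound 3 therefore cannot be sized, and the limit of > 50000 nM in this assay, at which 3 of the 3 values shown sit, is all that the numbers show. Compound 4 `Cc1nnsc1CO/N=C/c1c(C)nn(C)c1Oc1cccc(F)c1F` differs from compound 3 by 2,3-difluorophenyl in place of 4-methylphenyl on an oxygen on an aromatic ring. Within the data shown here, no measured step is readable, so none gives a direction for this change. Compound 4 is expected to remain at the limit, a step that the limit leaves unreadable from compound 3 to compound 4 in this assay. The value estimated for compound 4 is 70000 nM, with a range from 20000 nM to 250000 nM.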

Compound 4, half-maximal inhibitory concentration: 12200 nM
Compound 4: middle estimate off by 5.7-fold (0.76 log units), on the high side, outside the stated range (below it).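

The ring on this oxygen can move the read-out in this assay: 2,3-difluorophenyl gives an at least 4.0-fold lower number from compound 3 to compound 4 (0.61 log units; beyond the scatter), and it also gives an at least 4.0-fold lower number from compound 2 to compound 4 (0.61 log units; beyond the scatter) and an at least 4.0-fold lower number from compound 1 to compound 4 (0.61 log units; beyond the scatter). From the compounds shown here alone, each step is beyond the scatter, but its true size stays open, since one end of each is a limit. These are the first readable steps in the series, as the steps among the other compounds cannot be read, and those compounds share one limit: the limit of > 50000 nM in this assay, at which 3 of the 4 values shown sit.

Going by these compounds, whether both fluorines are needed remains open. So does whether a monofluorophenyl group, or a phenyl ring carrying an amine or a carboxylic acid, would lower the number further at this place.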